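A few compounds are considered here, and "the series" means these few. Any claim that something is new, unique, unknown or untested is made for them only; others in the source may bear on it.

In an assay on isolated protein for inhibition of alkaline phosphatase, tissue-nonspecific isozyme (Homo sapiens) (a lower number here means a stronger inhibitor, a higher number a weaker inhibitor), compound 1 `COc1ccc(C(F)(F)F)cc1S(=O)(=O)Nc1cccnc1` gives 183 nM, the highest of the three numbers recorded here. Compound 2 `COC(=O)c1cncc(NS(=O)(=O)c2cc(Cl)ccc2OC)c1` gives 65 nM and lies nearest to compound 1, a gap beyond the usual scatter, while compound 3 `COc1ccc(C(F)(F)F)cc1S(=O)(=O)Nc1cnc2ccccc2c1` gives 26 nM and lies furthest away. Neither compound differs from compound 1 in a single place, so no one-step comparison is available. Compound 4 `COC(=O)c1ccc(OC)c(S(=O)(=O)Nc2cccnc2)c1` differs from compound 1 by methoxycarbonyl in place of trifluoromethyl on an aromatic carbon. Lacking a measured step of this kind, the expected change is a 1.3-fold lower number from compound 1 to compound 4 (0.12 log units; within the scatter) in this assay, a modest move toward a lower number that may not clear the scatter. Compound 4 is therefore estimated at 140 nM, with a range from 45 nM to 450 nM.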

Compound 4, half-maximal inhibitory concentration: 1510 nM
Compound 4: middle estimate off by 11-fold (1.03 log units), on the low side; the measured number lies above the stated range.
By their numbers in this assay, from the lowest: compound 3; then compound 2; then compound 1; then compound 4.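

In this assay, replacing trifluoromethyl with methoxycarbonyl gives an 8.3-fold higher number from compound 1 to compound 4 (0.92 log units; beyond the scatter), the only single-place comparison among these compounds. This shows that the position, para to a methoxy group, does not treat these two groups alike, even though each has 4 heavy atoms. No measurement offered here bears on what lies behind this difference.

The compounds shown leave open how a nitrile, an amine or a carboxylic acid would compare with trifluoromethyl at this position. They also leave open whether the same change would give a similar step on the core of compound 3.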